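The compounds below may be only part of what the source reports. "The series", "measured", "known", "first", "only" and "open" are said of these compounds alone.

Measured compounds: compound 1 `O=C(NC[C@@H]1CCCc2cc(S(=O)(=O)c3cccc(F)c3)ccc21)c1ccc[nH]1` with 5.01 nM, compound 2 `O=C(NC[C@@H]1CCCc2cc(S(=O)(=O)c3cccc(F)c3)ccc21)[C@H]1CCCN1` with 0.631 nM, compound 3 `N=C(N)NC(=O)C[C@@H]1CCCc2cc(S(=O)(=O)c3cccc(F)c3)ccc21` with 0.631 nM, all in an assay on isolated protein for displacement of a labelled ligand from 5-hydroxytryptamine receptor 6 (Homo sapiens); a higher number here means a weaker inhibitor, a lower number a stronger inhibitor.

Compound 3 stands level with compound 2 at the digits given, and the two of them share the lowest numbers of the three. Its step away from compound 1 is large: a 7.9-fold lower number from compound 1 to compound 3 (0.90 log units; beyond the scatter). Between compound 2 and compound 3 there is no change at the digits printed from compound 2 to compound 3 (within the scatter).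

Compound 4 `CC(=O)N(C)C[C@@H]1CCCc2cc(S(=O)(=O)c3cccc(F)c3)ccc21` is the unmeasured one. It differs from compound 3 by a group of 5 heavy atoms (3 carbon, 1 nitrogen, 1 oxygen; no ring) in place of a group of 6 heavy atoms (2 carbon, 3 nitrogen, 1 oxygen; no ring), on a saturated chain carbon bound to a saturated ring carbon. Among the compounds with values here, the step that bears on this is the one from compound 1 to compound 3, in which the same six-atom group entered on the same chain carbon and brought the number down by a 7.9-fold lower number from compound 1 to compound 3 (0.90 log units; beyond the scatter). Compound 4 takes that group away again and puts in a group carrying no hydrogen-bond donor, so the step is expected to run in the opposite direction. Compound 2 gives no further guidance, since its step to compound 3 lies within the scatter. For compound 4 the expected step is a 32-fold higher number from compound 3 to compound 4 (1.50 log units; beyond the scatter), back past compound 1, and the estimate is 20 nM, with a range from 4 nM to 100 nM.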

Compound 4, inhibition constant: 1.59 nM
For compound 4 the middle estimate is 13-fold (1.10 log units) above the measured one; measured number below the stated range.
By their numbers in this assay, from the lowest: compounds 2 and 3 (each within the scatter of the next); then compound 4; then compound 1.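

At the saturated chain carbon bound to a saturated ring carbon, acetyl(methyl)amino, with 0 hydrogen-bond donors, costs little in this assay against the group it replaces: the change gives a 2.5-fold higher number from compound 3 to compound 4 (0.40 log units; beyond the scatter), and the comparison with the ((pyrrolidin-2-yl)carbonyl)amino group gives a 2.5-fold higher number from compound 2 to compound 4 (0.40 log units; beyond the scatter). Against ((1H-pyrrol-2-yl)carbonyl)amino the same small group gives a 3.2-fold lower number from compound 1 to compound 4 (0.50 log units; beyond the scatter), so compound 4 sits between the two lowest compounds and compound 1, and the low numbers at this position do not depend on a hydrogen-bond donor in the group or on a ring in it, although compound 1, which carries both, has the highest number of the four. Nothing measured here explains these differences.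

The compounds shown leave open how much of the number of compound 4 rests on the methyl on its nitrogen, which a plain acetylamino group or a free primary amine at the same carbon would test. They also leave open whether the number holds when the acetyl is extended to a longer chain such as propanoyl or butanoyl.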